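Dropping one methyl from compound 2: expected effect on A549 inhibition

The source may hold more compounds than are shown below. What is called first, only, known or untested is meant among the compounds shown, and "the series" means these compounds.

Working notes on the series. Three compounds of the shared core have numbers in a functional assay on A549 cells (Homo sapiens) for antiproliferative activity, with a stated time of 72 h, tested at 10 ug/mL (a lower number here means a weaker effect, a higher number a stronger effect of the compound at the concentration tested), so far. Compound 1 `O=c1[nH]nc2n(c1=O)CCN2c1ccccc1` gives 0%. Compound 2 `Cc1cccc(N2CCn3c2n[nH]c(=O)c3=O)c1C` gives in this assay 0%, level with compound 1 at the digits reported, and these two are together the lowest of the three numbers. Compound 3 `N=c1c(=O)[nH]nc2n1CCN2c1ccccc1Cl` gives in this assay 6%, the furthest from compound 2 but still within the scatter of it. For the measured compounds named here, no pair of measured compounds differs in only one place, so no measured step is available for any single change.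

Compound 4 `Cc1ccccc1N1CCn2c1n[nH]c(=O)c2=O` is not yet measured. It differs from compound 2 by hydrogen in place of methyl on an aromatic carbon, the site being on an aromatic carbon of a six-membered aromatic ring of carbon only, ortho to a methyl group and meta to a large group. Since all three measured numbers in this assay sit within the scatter of one another, there is nothing to suggest the change adds anything measurable. The expected step of a number 2 percentage points higher from compound 2 to compound 4 (within the scatter) is therefore none beyond the scatter. Compound 4 is expected in this assay at about 2%, with a range from 0% to 12%.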

Compound 4, a percentage reported as inhibition, at one concentration (the size of the read-out at that concentration, not a potency): 24%
Beside the measured number, compound 4's estimate is 22 percentage points below it; the measured number lies above the stated range.
By their numbers in this assay, from the lowest: compounds 1, 2 and 3 (each within the scatter of the next); then compound 4.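

In this assay, for the compounds shown here, taking away the methyl that sits on an aromatic carbon ortho to a methyl group gives a number 24 percentage points higher from compound 2 to compound 4 (beyond the scatter), the first step beyond the scatter, so this site is not silent even though the earlier numbers gave no sign of it. Going the other way on the ring, methyl in place of hydrogen on an aromatic carbon gives a number 24 percentage points higher from compound 1 to compound 4 (beyond the scatter), so the compound with one methyl stands above both the compound with none and the compound with two, and the number does not follow the count of methyl groups across these three compounds. Nothing available explains why either change moves the number.

Both steps are modest and rest on a read-out at a single concentration, so they show a difference in inhibition at that concentration, not a difference in potency. From the compounds shown here alone, it stays open whether a methoxy group, an ethyl group or an amine at the site of the lost methyl would leave the number where compound 4 stands or return it to where compound 2 stands, and whether a methyl elsewhere on the ring would do the same.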